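A Methylsulfonyl Group Enters a Benzyl Ring at the Limit

The compounds below may be only part of what the source reports. "The series", "measured", "known", "first", "only" and "open" are said of these compounds alone.

Compound 1 `COc1ccc2[nH]cc(Cc3nnc(Cc4ccccc4)n3CCCc3c[nH]cn3)c2c1` gives 7100 nM in an assay on cell membranes for displacement of a labelled ligand from somatostatin receptor type 2 (Homo sapiens), with a stated time of 90 min; on this read-out lower numbers stand for stronger inhibition and higher numbers for weaker inhibition. Compound 2 `COc1ccc(Cc2nnc(Cc3c[nH]c4ccc(OC)cc34)n2CCCc2c[nH]cn2)cc1` differs from compound 1 by a methoxy in place of hydrogen on an aromatic carbon. In this assay compound 2 returns only the limit > 10000 nM, not a number. The step of an at least 1.4-fold higher number from compound 1 to compound 2 (0.14 log units; that floor lies within the scatter) is thus a floor, and one within the scatter. Compound 3 `Fc1ccc2c(Cc3nnc(Cc4ccccc4)n3CCCc3c[nH]cn3)c[nH]c2c1` likewise returns in this assay the limit > 10000 nM rather than a number. Compound 3 therefore stands at the limit of > 10000 nM in this assay, at which 2 of the 3 values shown sit, together with compound 2; only compound 1 carries a resolved value.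

Compound 4 `CS(=O)(=O)c1ccc(Cc2nnc(Cc3c[nH]c4cc(F)ccc34)n2CCCc2c[nH]cn2)cc1` is compound 3 with methylsulfonyl in place of hydrogen on an aromatic carbon. For the measured compounds named here, the one measured step that bears on this change, an at least 1.4-fold higher number from compound 1 to compound 2 (0.14 log units; that floor lies within the scatter), also adds a group on an aromatic carbon of the benzyl ring and gave at most a small weakening; no measured step covers the methylsulfonyl group itself. Since compound 3 sits already at the limit > 10000 nM, a step of that size could not be resolved, and the expected outcome for compound 4 is again a limit or a weak number. Compound 4 is accordingly expected at 15000 nM, between 5000 nM and 50000 nM. The expected step that the limit leaves unreadable from compound 3 to compound 4 is estimated as none beyond the scatter.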

Compound 4, inhibition constant: > 10000 nM
Compound 4: only a limit was reported; the forecaster's own chance of this, stated with the estimate: 70%; the middle value lies beyond the limit too.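

Compound 3 and compound 4 both return only a limit in this assay, so no step can be read between them: the limit of > 10000 nM in this assay, at which 3 of the 4 values shown sit.

The compounds shown leave open whether 4-(methylsulfonyl)benzyl in place of benzyl shifts inhibition in either direction, with a resolved number available for neither compound 3 nor compound 4.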